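Furan-2-yl entering on the chain carbon of compound 2

A few compounds are considered here, and "the series" means these few. Any claim that something is new, unique, unknown or untested is made for them only; others in the source may bear on it.

Among the measured compounds shown here, in a toxicity assay on WI-38 cells (Homo sapiens) for cytotoxicity, read by MTT assay, with a stated time of 48 h (on this read-out higher numbers stand for weaker inhibition and lower numbers for stronger inhibition), compound 2 `CC1=C([Se]c2ccc(NCc3nnnn3C(C)(C)C)cc2)C(=O)c2ccccc2C1=O` gives 48000 nM, one of only two numbers so far. In this assay compound 1 `Cc1ccc(C(Nc2ccc([Se][Se]c3ccc(NC(c4ccc(C)cc4)c4nnnn4C(C)(C)C)cc3)cc2)c2nnnn2C(C)(C)C)cc1` gives 41000 nM, within the scatter of compound 2. Compound 3 `CC1=C([Se]c2ccc(NC(c3ccco3)c3nnnn3C(C)(C)C)cc2)C(=O)c2ccccc2C1=O` is unmeasured; it differs from compound 2 by furan-2-yl in place of hydrogen on a saturated chain carbon bound to an aromatic carbon and a nitrogen on an aromatic ring. For the measured compounds named here, no measured step covers this change. Compound 1, which also bears an aromatic group rather than hydrogen on a saturated chain carbon bound to an aromatic carbon and a nitrogen on an aromatic ring, sits within the scatter of compound 2, so no step beyond the scatter is expected. Compound 3 is estimated at 42000 nM, range 15000 nM to 110000 nM. The expected step is a 1.1-fold lower number from compound 2 to compound 3 (0.06 log units; within the scatter).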

Compound 3, half-maximal inhibitory concentration: 5000 nM
Compound 3: middle estimate off by 8.4-fold (0.92 log units), on the high side; measured number below the stated range.
By their numbers in this assay, from the lowest: compound 3; then compounds 1 and 2 (each within the scatter of the next).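

In this assay, furan-2-yl in place of hydrogen on the saturated chain carbon bound to an aromatic carbon and a nitrogen on an aromatic ring gives a 9.6-fold lower number from compound 2 to compound 3 (0.98 log units; beyond the scatter). Among the compounds shown here, the two earlier compounds offered no step at all, so this is the first sign that the read-out responds to substitution at this position. Nothing available explains the size of this step.

On these data alone, whether the step is specific to furan-2-yl or extends to other rings at this carbon remains open. How thiophen-2-yl or a plain methyl would read here is also unknown.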